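Shortening the side chain of a hydroxamic acid to a benzyl group

The source may hold more compounds than are shown below. What is called first, only, known or untested is meant among the compounds shown, and "the series" means these compounds.

Three compounds share a core and differ in the chain on the aromatic nitrogen. In a functional assay on HepG2 cells (Homo sapiens) for antiproliferative activity, read by MTT assay, with a stated time of 48 h (a lower number here means a stronger inhibitor of growth, a higher number a weaker inhibitor of growth), compound 1 `Cc1ccc(OCCCN(Cc2ccc(C(=O)NO)cc2)c2ncc(-c3ccc(C)cc3)s2)cc1` gives 12200 nM, compound 2 `Cc1ccc(-c2cnc(N(CCCCOc3ccccc3)Cc3ccc(C(=O)NO)cc3)s2)cc1` gives 16600 nM and compound 3 `Cc1ccc(-c2cnc(N(CCCOc3ccccc3)Cc3ccc(C(=O)NO)cc3)s2)cc1` gives 23400 nM. The steps of a 1.9-fold higher number from compound 1 to compound 3 (0.28 log units; within the scatter) and a 1.4-fold higher number from compound 2 to compound 3 (0.15 log units; within the scatter) are within the scatter, so compound 3 stands with the other two rather than apart from them. Compound 4 `Cc1ccc(-c2cnc(N(Cc3ccccc3)Cc3ccc(C(=O)NO)cc3)s2)cc1` differs from compound 3 by phenyl in place of 2-phenoxyethyl on a saturated chain carbon bound to a nitrogen on an aromatic ring. The chain steps that bear on this, a 1.4-fold higher number from compound 1 to compound 2 (0.13 log units; within the scatter) and a 1.4-fold higher number from compound 2 to compound 3 (0.15 log units; within the scatter), were both within the scatter, so no step beyond the scatter is expected in this assay for a 1.1-fold higher number from compound 3 to compound 4 (0.03 log units; within the scatter). Compound 4 is therefore estimated at 25000 nM, between 10000 nM and 60000 nM.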

Compound 4, concentration for 50% growth inhibition: 34000 nM
Beside the measured number, compound 4's estimate is 1.4-fold (0.13 log units) below it; low and high end bracket the measured number.
By their numbers in this assay, from the lowest: compounds 1, 2, 3 and 4 (each within the scatter of the next, the first and the last beyond it).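

Among these compounds, replacing the chain with benzyl gives the first steps at this position that lie beyond the scatter in this assay and both are modest (a 2.0-fold higher number from compound 2 to compound 4 (0.31 log units; beyond the scatter) and a 2.8-fold higher number from compound 1 to compound 4 (0.45 log units; beyond the scatter)). The change from 3-phenoxypropyl to benzyl stays within the scatter (a 1.5-fold higher number from compound 3 to compound 4 (0.16 log units; within the scatter)), so the weakening appears only against compound 1 and compound 2. No evidence on the cause of these steps is at hand. The compounds shown leave open how an amine or a carboxylic acid at the chain end, or a longer chain, would compare.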